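The compounds below may be only part of what the source reports. "The series", "measured", "known", "first", "only" and "open" are said of these compounds alone.

Working notes on the series

Compound 1 `CC(=O)c1cc2ccc(OCCCn3cc(CNC(=O)CCCCC4CCSS4)nn3)cc2oc1=O` and compound 2 `CCOC(=O)c1cc2ccc(OCCCn3cc(CNC(=O)CCCCC4CCSS4)nn3)cc2oc1=O` share one core; compound 3 `CC(=O)c1cc2ccc(OCCCCCn3cc(CNC(=O)CCCCC4CCSS4)nn3)cc2oc1=O` and compound 4 `CCOC(=O)c1cc2ccc(OCCCCCn3cc(CNC(=O)CCCCC4CCSS4)nn3)cc2oc1=O` share another, and the difference between the two cores is not broken down here. In a functional assay on PC-12 cells (Rattus norvegicus) for cytotoxicity, read by MTT assay, with stated times of 3 h and 2 h, tested at 5 uM (on this read-out lower numbers stand for a weaker effect and higher numbers for a stronger effect at the one concentration tested), compound 1 gives 37.5%, and in this assay compound 2 gives 32.4%. The change ethoxy in place of methyl on a carbonyl carbon gives a number 5.1 percentage points lower from compound 1 to compound 2 (within the scatter). In this assay compound 3 gives 22.2%, the lowest of the three numbers, with compound 2 nearest and compound 1 furthest, both beyond the scatter. Compound 4 differs from compound 3 by ethoxy in place of methyl on a carbonyl carbon, the same change seen from compound 1 to compound 2, made twice in all among these compounds. Its place line reads the same in both pairs, so this is the same change on the other core. The expected step is a number 4.2 percentage points lower from compound 3 to compound 4 (within the scatter), resting on the size of a number 5.1 percentage points lower from compound 1 to compound 2 (within the scatter), which was within the scatter. For compound 4 in this assay the estimate is 18%, expected to fall between 8% and 30%.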

Compound 4, a percentage reported as activity, at one concentration (the size of the read-out at that concentration, not a potency): 36.4%
Compound 4: the middle estimate sits 18.4 percentage points below what was measured, and the stated range ends below it.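

In this assay, ethoxy in place of methyl on a carbonyl carbon gives a number 14.2 percentage points higher from compound 3 to compound 4 (beyond the scatter), so the change does not carry over from one core to the other with a single direction or size: the same change on two cores in this assay, a number 5.1 percentage points lower (within the scatter) from compound 1 to compound 2 and a number 14.2 percentage points higher (beyond the scatter) from compound 3 to compound 4, 19.3 percentage points apart, beyond the scatter of two such steps. Within the data shown here, for this pair of cores, the step on the core of compound 1 is therefore no guide to the step on the core of compound 3. Among these compounds, this does not show why the two cores part, nor how the change would behave on any further core: only two pairs stand here, the difference between the cores is not broken down, and the read-out comes from one concentration and is not a potency.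

Still open, going by these compounds, is whether the change follows either pattern on a core with a longer chain than that of compound 3. Also open, on these data alone, is how an amine or a hydroxyl group in place of the ethoxy on that carbonyl carbon would read on either core.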